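Exchanging Tert-Butyl for Methylsulfanyl: Expected Permeability Shift

The source may hold more compounds than are shown below. What is called first, only, known or untested is meant among the compounds shown, and "the series" means these compounds.

Compound 2 `Cc1cc(NC(=O)Nc2ccccc2C(C)(C)C)c2ccccc2n1` stands lowest of the two numbers measured in an ADME assay for permeability, using PAMPA, at pH 7.4 (on this read-out lower numbers stand for lower permeability and higher numbers for higher permeability), where compound 2 gives 27 10^-6 cm/s. Among the compounds with values here, compound 1 `Cc1cc(NC(=O)Nc2ccccc2OC(F)(F)F)c2ccccc2n1` gives 1110 10^-6 cm/s; the only measured step is a 41-fold lower number from compound 1 to compound 2 (1.61 log units; beyond the scatter). Compound 3 `CSc1ccccc1NC(=O)Nc1cc(C)nc2ccccc12` differs from compound 2 by methylsulfanyl in place of tert-butyl on an aromatic carbon. Within the data shown here, that measured step bears on this change only partly: the group leaving here is the one that entered there, while no measured compound carries methylsulfanyl. A rise from compound 2 is therefore expected, set smaller than that measured step. Compound 3 is estimated at 200 10^-6 cm/s, within 50 10^-6 cm/s to 800 10^-6 cm/s. The expected step of a 7.4-fold higher number from compound 2 to compound 3 (0.87 log units; beyond the scatter) lies beyond the scatter.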

Compound 3, apparent permeability: 1260 10^-6 cm/s
For compound 3 the middle estimate is 6.3-fold (0.80 log units) below the measured one; the whole stated range lies below it.
By their numbers in this assay, from the lowest: compound 2; then compounds 1 and 3 (each within the scatter of the next).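

Methylsulfanyl in place of tert-butyl on this aromatic carbon gives a 47-fold higher number from compound 2 to compound 3 (1.67 log units; beyond the scatter) in this assay, while methylsulfanyl in place of trifluoromethoxy gives a 1.1-fold higher number from compound 1 to compound 3 (0.06 log units; within the scatter). Two different groups at this position thus give numbers within the scatter of each other, and among these three compounds only compound 2, with tert-butyl, stands apart. Nothing available accounts for this gap. Going by these compounds, whether isopropyl would stay low like tert-butyl remains open, as does where methoxy or chlorine at this position would fall.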